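Piperidine sulfonamides in mice: extending the acetamido arm

The compounds below may be only part of what the source reports. "The series", "measured", "known", "first", "only" and "open" are said of these compounds alone.

Three sulfonamides built on a saturated six-membered ring with one nitrogen have been tested in a functional assay on the whole organism with Mus musculus as the target, with a stated time of 30 min; on this read-out lower numbers stand for an effect already at smaller amounts and higher numbers for an effect only at larger amounts of compound. Compound 1 `CC(=O)NC1CCCN(S(=O)(=O)c2ccc(F)cc2)C1` gives 1 mg/kg in this assay. Compound 3 `CCC(=O)N1CCC(CNS(=O)(=O)c2ccc(F)cc2)CC1` gives 1 mg/kg, so compound 1 and compound 3 are level at the digits shown and within the scatter of each other; together they hold the lowest numbers of the three. Compound 2 `CCC(=O)N1CCCC(NS(=O)(=O)c2ccc(F)cc2)C1` gives 10 mg/kg, a number far enough from compound 1 to lie beyond the scatter.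

The next compound, compound 4 `CCC(=O)NCC1CCCN(S(=O)(=O)c2ccc(F)cc2)C1`, differs from compound 1 in one place: (propanoylamino)methyl in place of acetamido on a saturated ring carbon. Among the compounds with values here, no measured pair here shows such a change in isolation, so its effect in this assay can only be guessed. Since compound 1 and compound 3 carry a propanoyl group and a methylene-linked chain in different arrangements yet give the same number, the step is expected to be small, in either direction or none beyond the scatter. Compound 4 is therefore estimated at 2 mg/kg, with a range of 0.5 mg/kg to 10 mg/kg. This estimate amounts to a 2.0-fold higher number from compound 1 to compound 4 (0.30 log units; within the scatter).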

Compound 4, minimum effective dose: 10 mg/kg
Beside the measured number, compound 4's estimate is 5.0-fold (0.70 log units) below it; the measured number falls inside the stated range.
By their numbers in this assay, from the lowest: compounds 1 and 3 (each within the scatter of the next); then compounds 2 and 4 (each within the scatter of the next).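

In this assay, within the data shown here, the replacement of acetamido by (propanoylamino)methyl on a saturated ring carbon gives a 10-fold higher number from compound 1 to compound 4 (1.00 log units; beyond the scatter) and is the first single-place change that can be read. It shows that the number at this position, two ring bonds from the ring nitrogen, responds to this change even though the entering group keeps the same counts of hydrogen-bond donors and acceptors and carries no net charge. No supporting measurement is available to explain this step. The step combines a longer acyl part with an added methylene link, and the compounds shown do not separate the two. Going by these compounds, whether acetamidomethyl or propanoylamino at this place would keep the lower number, and how an aminomethyl group or a longer chain would read, remains open.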